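The source may report more compounds than this note shows. Statements on the series, on what has been measured and on what is new or still open speak of the compounds shown alone.

Compound 3 `COc1cc(C)cc(-c2nn(CC#N)cc2-c2ccnc(-c3ccc(N(C)C)cc3)c2)c1` returns only a limit in a functional assay on OVCAR-5 cells (Homo sapiens) for inhibition, read by sulforhodamine B assay, with a stated time of 48 h (a lower number here means a stronger inhibitor of growth, a higher number a weaker inhibitor of growth), > 100000 nM, which is the limit of the assay itself (the limit of > 100000 nM in this assay, at which 2 of the 3 values shown sit). Compound 1 `COc1cc(C)cc(-c2c(-c3ccnc(-c4ccc(C(C)=O)cc4)c3)cnn2CC#N)c1` likewise returns a limit, > 100000 nM. Compound 2 `Cc1cc(O)cc(-c2nn(CC#N)cc2-c2ccnc(-c3ccc(Oc4ccccc4)cc3)c2)c1` returns a number, 19200 nM. Compound 4 `Cc1cc(O)cc(-c2nn(CC#N)cc2-c2ccnc(-c3ccc(N(C)C)cc3)c2)c1` has not been measured in this assay. It differs from compound 3 in one place: hydrogen in place of methyl on an oxygen on an aromatic ring. For the measured compounds named here, no step between two measured compounds is available, so the size of this change cannot be read directly; compound 2, which carries the hydroxy, is the one compound with a number, while compound 1 and compound 3, with methoxy, sit at the limit. A step toward stronger inhibition is therefore expected, estimated at an at least 2.5-fold lower number from compound 3 to compound 4 (0.39 log units; beyond the scatter). Compound 4 is expected to give 40000 nM, within 8000 nM to 100000 nM.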

Compound 4, concentration for total growth inhibition: 60400 nM
Compound 4: the middle estimate sits 1.5-fold (0.18 log units) below what was measured; the range from low to high includes it.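

In this assay, hydroxy in place of methoxy on the aromatic ring gives an at least 1.6-fold lower number from compound 3 to compound 4 (0.21 log units; that floor lies within the scatter), so compound 4 returns a number where its methoxy partner does not, although the size of the step remains unsettled. Compound 3 stands only at a limit of the assay: the limit of > 100000 nM in this assay, at which 2 of the 4 values shown sit. With the hydroxy kept, dimethylamino in place of phenoxy gives a 3.1-fold higher number from compound 2 to compound 4 (0.50 log units; beyond the scatter), so the number also depends on this second place. From the compounds shown here alone, it remains open how an amino group or a carboxylic acid in place of the hydroxy would read, and whether the methoxy to hydroxy step would hold with phenoxy in place of dimethylamino.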